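A few compounds are considered here, and "the series" means these few. Any claim that something is new, unique, unknown or untested is made for them only; others in the source may bear on it.

Going by the values given here, compound 3 `CC(C)CC(=O)N1CCc2cc(CNC(=O)c3cccnc3)ccc21` stands second highest of the three numbers so far in an assay on HEK293 cells for inhibition of Indoleamine 2,3-dioxygenase 1 (Homo sapiens), tested at 10 uM (a lower number here means less inhibition, a higher number more inhibition at the concentration tested (going by the name of the read-out)), where compound 3 gives 86%. Compound 1 `CCC(=O)N1CCc2cc(CNC(=O)c3ccccc3)ccc21` gives 87%, within the scatter of compound 3, while compound 2 `CC(C)CC(=O)N1CCc2cc(CNC(=O)C3CC3)ccc21` gives 35%. Among the compounds with values here, the one measured step that alters a single place is a number 51 percentage points higher from compound 2 to compound 3 (beyond the scatter). Compound 4 `COCC(=O)NCc1ccc2c(c1)CCN2C(=O)CC(C)C` differs from compound 3 by methoxymethyl in place of pyridin-3-yl on a carbonyl carbon. That earlier step bears on this one: compound 2, with cyclopropyl on the same carbonyl carbon, stands far lower than compound 3, so a drop of comparable direction is expected when the ring leaves again. Compound 4 is therefore expected to give 40%, with a range from 15% to 65%. The expected step is a number 46 percentage points lower from compound 3 to compound 4 (beyond the scatter).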

Compound 4, a percentage reported as inhibition, at one concentration (the size of the read-out at that concentration, not a potency): 20%
For compound 4 the middle estimate is 20 percentage points above the measured one, within the range that was stated.
By their numbers in this assay, from the lowest: compound 4; then compound 2; then compounds 3 and 1 (each within the scatter of the next).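

On this carbonyl carbon, methoxymethyl gives a number 66 percentage points lower from compound 3 to compound 4 (beyond the scatter) in this assay, so a second replacement for pyridin-3-yl also stands far below compound 3. The two replacements are not equivalent either, with a number 15 percentage points lower from compound 2 to compound 4 (beyond the scatter) as a modest step. Nothing measured here accounts for these differences. On these data alone, whether a longer alkyl chain or a carboxylic acid on this carbonyl carbon would stay low, or come close to compound 3, remains open.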